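The source may report more compounds than this note shows. Statements on the series, on what has been measured and on what is new or still open speak of the compounds shown alone.

Compound 1 `OC1CCN(c2ncnc3[nH]cc(-c4cccc(Cl)c4)c23)CC1` is one of three compounds tested in an assay for inhibition of serine/threonine-protein kinase 4 (Homo sapiens), read by luminescence and ADP-Glo, in the presence of a further agent that is not named here (on this read-out lower numbers stand for stronger inhibition and higher numbers for weaker inhibition), where compound 1 gives 80 nM. Compound 3 `Clc1cccc(-c2c[nH]c3ncnc(N4CCCCC4)c23)c1` gives 48 nM and compound 2 `CC1(O)CCN(c2ncnc3[nH]cc(-c4cccc(Cl)c4)c23)CC1` gives 145 nM, so compound 1 stands second highest of the three, though both other numbers lie within the scatter of it: a 1.7-fold lower number from compound 1 to compound 3 (0.22 log units; within the scatter) and a 1.8-fold higher number from compound 1 to compound 2 (0.26 log units; within the scatter). Among the measured compounds shown here, only the step of a 3.0-fold lower number from compound 2 to compound 3 (0.48 log units; beyond the scatter) reaches beyond the scatter. Compound 4 `CC(CO)CN(C)c1ncnc2[nH]cc(-c3cccc(Cl)c3)c12` differs from compound 1 by a group of 7 heavy atoms (5 carbon, 1 nitrogen, 1 oxygen; no ring) in place of a group of 7 heavy atoms (5 carbon, 1 nitrogen, 1 oxygen; one six-membered non-aromatic ring with 1 hetero atom), on an aromatic carbon. For the measured compounds named here, no measured step removes the ring; the two steps that alter the same group stayed within the scatter, so a small shift at most, likely toward a higher number, is expected, about a 1.6-fold higher number from compound 1 to compound 4 (0.21 log units; within the scatter). For compound 4 the estimate in this assay is 130 nM, from 45 nM to 400 nM.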

Compound 4, half-maximal inhibitory concentration: 38 nM
Compound 4: middle estimate off by 3.4-fold (0.53 log units), on the high side; the measured number lies below the stated range.
By their numbers in this assay, from the lowest: compounds 4, 3, 1 and 2 (each within the scatter of the next, the first and the last beyond it).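

Losing the ring of the 4-hydroxypiperidin-1-yl group costs nothing at this aromatic carbon: the step of a 2.1-fold lower number from compound 1 to compound 4 (0.32 log units; beyond the scatter) goes toward stronger inhibition, so the ring is not needed here. The same ring-free group shows a 1.3-fold lower number from compound 3 to compound 4 (0.10 log units; within the scatter) against the piperidin-1-yl group, no real difference, and a 3.8-fold lower number from compound 2 to compound 4 (0.58 log units; beyond the scatter) against the 4-hydroxy-4-methylpiperidin-1-yl group, the largest step in this set. Nothing at hand explains these shifts.

On these data alone, whether the hydroxy on the open chain matters stays open, as does whether an amine or a carboxylic acid in its place, or a longer chain, would hold this level.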